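The source may report more compounds than this note shows. Statements on the series, on what has been measured and on what is new or still open speak of the compounds shown alone.

Of the compounds shown here, two built on a shared core have been measured in an assay on CHO cells for agonist activity at Neuronal acetylcholine receptor; alpha3/alpha6/beta2/beta3 (Homo sapiens), read by FLIPR and calcium flux; on this read-out lower numbers stand for an effect already at smaller amounts and higher numbers for an effect only at larger amounts of compound. Compound 1 `CC(C)C(=O)N1CC2CC(C1)N2` gives 16000 nM in this assay, and compound 2 `O=C(CC1C=CCC1)N1CC2CC(C1)N2` gives 21000 nM. Going by the values given here, these two numbers sit within the usual scatter of each other, so neither compound can be set apart from the other on this read-out, and no step between them can be drawn.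

Compound 3 `O=C([C@@H]1C[C@H]1F)N1CC2CC(C1)N2` has not yet been measured. It differs from compound 1 in one place: 2-fluorocyclopropyl in place of isopropyl on a carbonyl carbon. Among the compounds with values here, no pair of measured compounds shows what such an exchange does, so the data give no direction for it. For that reason the step of a 1.1-fold lower number from compound 1 to compound 3 (0.03 log units; within the scatter) is expected to fall within the usual scatter rather than beyond it. Compound 3 is therefore estimated at 15000 nM, with a range from 5000 nM to 45000 nM.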

Compound 3, half-maximal effective concentration: 53 nM
For compound 3 the middle estimate is 280-fold (2.45 log units) above the measured one; measured number outside the range, below it.
By their numbers in this assay, from the lowest: compound 3; then compounds 1 and 2 (each within the scatter of the next).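

In this assay, the group on this carbonyl carbon proves able to shift the number strongly: 2-fluorocyclopropyl in place of isopropyl gives a 300-fold lower number from compound 1 to compound 3 (2.48 log units; beyond the scatter) on the otherwise unchanged core. Compound 1 and compound 2 sit within the scatter of each other despite carrying different groups at this place, and so gave no sign that a change here could have an effect of this size. No available evidence bears on the cause of this step.

The step brings in a three-membered ring, a fluorine and two defined stereocentres together, and the compounds shown do not separate their contributions. As far as these compounds go, whether plain cyclopropyl, 2-methylcyclopropyl or the opposite stereoisomer of 2-fluorocyclopropyl on the same carbonyl carbon would give a similar number remains open.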